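Solubility notes on compound 4 and its measured neighbours

The source may report more compounds than this note shows. Statements on the series, on what has been measured and on what is new or still open speak of the compounds shown alone.

Compound 1 `CNC(=O)c1cc(C(=O)NC2CC2)cn(Cc2ccc3nc[nH]c3c2)c1=O`: in a physicochemical assay for solubility (a higher number here means a more soluble compound, a lower number a less soluble compound), compound 1 gives >= 163 ug/mL, which is a limit of the assay and not a number.
Compound 2 `CNC(=O)c1cc(C(=O)NC2CC2)cn(Cc2ccc(OC)cc2)c1=O`: in this assay compound 2 gives >= 143 ug/mL, also a limit.
Compound 3 `CNC(=O)c1cc(C(=O)NC2CC2)cn(Cc2cccc(C#N)c2)c1=O`: in this assay compound 3 gives >= 148 ug/mL, again a limit.

Compound 3 therefore stands only at a limit, and the two further values shown are limits as well, so none of the three can be ordered against the others. The steps a step that the two limits leave unreadable from compound 1 to compound 2, a step that the two limits leave unreadable from compound 1 to compound 3 and a step that the two limits leave unreadable from compound 2 to compound 3 carry no readable size because of the limit of >= 143 ug/mL in this assay, at which 1 of the 3 values shown sits, the limit of >= 148 ug/mL in this assay, at which 1 of the 3 values shown sits, and the limit of >= 163 ug/mL in this assay, at which 1 of the 3 values shown sits, hold each of the three values.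

Compound 4 `CNC(=O)c1cc(C(=O)NC2CC2)cn(Cc2ccccc2F)c1=O` differs from compound 3 by 2-fluorophenyl in place of 3-cyanophenyl on a saturated chain carbon bound to an aromatic nitrogen. All three measured steps change the same place in the structure and bear on this one, yet each is unreadable, so they give no size in either direction. No step beyond the scatter is expected; the expected step is a step that the limit leaves unreadable from compound 3 to compound 4. In this assay compound 4 is estimated at 150 ug/mL, with a range from 60 ug/mL to 300 ug/mL, most likely reported again as a limit.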

Compound 4, solubility: >= 145 ug/mL
Compound 4: only a limit was reported; the forecaster's own chance of this, stated with the estimate: 70%; the middle value lies beyond the limit too.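

In this assay compound 4 gives >= 145 ug/mL, a limit of the assay and not a number, so its steps to compound 1, compound 2 and compound 3 cannot be read. The compounds shown leave open whether these four aryl groups differ at all in this assay.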